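Fluorine on the Benzyl Ring of Compound 3

The source may report more compounds than this note shows. Statements on the series, on what has been measured and on what is new or still open speak of the compounds shown alone.

In a functional assay on OVCAR-3 cells (Homo sapiens) for antiproliferative activity, read by WST assay, with a stated time of 72 h (on this read-out higher numbers stand for weaker inhibition and lower numbers for stronger inhibition), three compounds have been measured:
Compound 1, `Nc1n/c(=N\CCCCc2ccccc2)nc(N)c2c1ncn2Cc1ccccc1`, gives 37300 nM.
Compound 2, `CCCCCCCCCCCCCCCCCC/N=c1\nc(N)c2ncn(Cc3ccccc3)c2c(N)n1`, gives 4950 nM.
Compound 3, `CCCCCCCC/N=c1\nc(N)c2ncn(Cc3ccccc3)c2c(N)n1`, gives 4980 nM.

Compound 3 thus stands second highest of the three numbers; its value and that of compound 2 lie within the scatter of each other, while compound 1 is clearly further away. Compound 4, `CCCCCCCC/N=c1\nc(N)c2ncn(Cc3ccc(F)cc3)c2c(N)n1`, differs from compound 3 only by fluoro in place of hydrogen on an aromatic carbon. Neither measured step touches this ring: a 7.5-fold lower number from compound 1 to compound 3 (0.87 log units; beyond the scatter) and a 1.0-fold higher number from compound 2 to compound 3 (0.00 log units; within the scatter) both concern the chain attached to the double-bonded nitrogen. Going by the values given here, with no step bearing on the benzyl ring, the expectation for this assay is a change within the scatter, a 1.1-fold lower number from compound 3 to compound 4 (0.04 log units; within the scatter). Compound 4 is therefore estimated at 4500 nM, between 1500 nM and 13000 nM.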

Compound 4, half-maximal inhibitory concentration: 4300 nM
Compound 4: middle estimate off by 1.0-fold (0.02 log units), on the high side, and the stated range covers the measured number.
By their numbers in this assay, from the lowest: compounds 4, 2 and 3 (each within the scatter of the next); then compound 1.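

Where the earlier compounds differ only in the chain, this pair differs on the benzyl ring. In this assay, the change to 4-fluorobenzyl, with the fluoro para to a large group, gives a 1.2-fold lower number from compound 3 to compound 4 (0.06 log units; within the scatter) and so leaves the read-out effectively unmoved. No measurement here explains why the two compounds read alike.

Still open, on these data alone, is whether a bulkier group on the same ring carbon, such as trifluoromethyl or methoxy, would also leave the number in place. Also open, as far as these compounds go, is whether 4-fluorobenzyl would behave the same way alongside a different chain, such as the butyl-linked phenyl of compound 1.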